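Acylsulfonamide in place of acylsulfonohydrazide at the carboxamide terminus

A few compounds are considered here, and "the series" means these few. Any claim that something is new, unique, unknown or untested is made for them only; others in the source may bear on it.

Measured compounds:
compound 1, `CC[C@H](C)[C@H](NC(=O)c1cccc(Cn2ccnc2)c1)C(=O)NNS(=O)(=O)c1ccccc1`, > 100000 nM
compound 2, `CC[C@H](C)[C@H](NC(=O)c1cccc(Cn2ccnc2)c1)C(=O)NNS(=O)(=O)c1ccc(OC)cc1`, 9200 nM

Compound 1 was tested in an assay on HEK293 cells for displacement of a labelled ligand from Type-2 angiotensin II receptor (Homo sapiens) (on this read-out lower numbers stand for stronger inhibition and higher numbers for weaker inhibition), and gave only a limit, (the limit of > 100000 nM in this assay, at which 1 of the 2 values shown sits), so no number is known for it. Compound 2 carries a methoxy in place of hydrogen on an aromatic carbon and gave a number, an at least 10-fold lower number from compound 1 to compound 2 (1.03 log units; beyond the scatter). Compound 3, `CC[C@H](C)[C@H](NC(=O)c1cccc(Cn2ccnc2)c1)C(=O)NS(=O)(=O)c1ccccc1`, is not yet measured; it differs from compound 1 by phenylsulfonyl in place of (phenylsulfonyl)amino on an amide-type nitrogen. Within the data shown here, no measured step touches this part of the structure, so the size of its effect is unknown. Since compound 1 sits at the limit, the account can only say that compound 3 is expected to stay near that limit, with some chance of a measurable number: the step of an at least 1.2-fold lower number from compound 1 to compound 3 (0.09 log units; that floor lies within the scatter) is the expected one. The estimate for compound 3 is 80000 nM, in a range from 10000 nM to 300000 nM.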

Compound 3, inhibition constant: 18000 nM
For compound 3 the middle estimate is 4.4-fold (0.65 log units) above the measured one; the range from low to high includes it.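

Compound 1 gives only a limit in this assay: the limit of > 100000 nM in this assay, at which 1 of the 3 values shown sits. Phenylsulfonyl in place of (phenylsulfonyl)amino on an amide-type nitrogen gives an at least 5.5-fold lower number from compound 1 to compound 3 (0.74 log units; beyond the scatter), so this part of the structure, which the earlier step left untouched, affects the read-out even with the phenyl ring unsubstituted, though the step is only a floor. Two separate single changes from compound 1, methoxy on an aromatic carbon and this one on the amide-type nitrogen, now each lead to a measurable number.

Going by these compounds, the true size of the step stays open, as does whether a methoxy on the phenyl ring of compound 3 would lower the number further. Also open, on these data alone, is how a carboxylic acid at this terminus, or a methyl group on the amide-type nitrogen, would read.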